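The source may hold more compounds than are shown below. What is called first, only, known or untested is meant among the compounds shown, and "the series" means these compounds.

In a physicochemical assay for lipophilicity, read by mass spectrometry (on this read-out higher numbers stand for higher lipophilicity and lower numbers for lower lipophilicity), two compounds have numbers so far
Compound 1 `COc1cc2c(cc1OC)C(=O)C(C(=O)Nc1ccccc1)C2` gives 2.2
Compound 2 `CCc1cccc(NC(=O)C2Cc3cc(OC)c(OC)cc3C2=O)c1` gives 3.11

Of these two numbers, compound 2 holds the higher one: at 3.11 it stands above compound 1 at 2.2 and the gap lies beyond the usual scatter. The next molecule is compound 3 `COc1ccccc1NC(=O)C1Cc2cc(OC)c(OC)cc2C1=O` and it has 2-methoxyphenyl in place of 3-ethylphenyl on an amide-type nitrogen with the rest of compound 2 unchanged.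

Among the compounds with values here, only one measured step bears on this change. It is a number 0.91 log units higher from compound 1 to compound 2 (beyond the scatter) and it came with ethyl in place of hydrogen on an aromatic carbon, a modest step. Within the data shown here, no measured step covers a methoxy group, so that part of the change remains open. With the ethyl gone, most of the rise seen in a number 0.91 log units higher from compound 1 to compound 2 (beyond the scatter) is expected to disappear, leaving a number closer to compound 1 at 2.2 but probably still somewhat higher. The expected outcome in this assay is a number 0.61 log units lower from compound 2 to compound 3 (beyond the scatter) as a downward step of modest size. The estimated value for compound 3 is 2.5 with 2.1 to 2.9 as the expected range.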

Compound 3, partition coefficient: 2.08
For compound 3 the middle estimate is 0.42 log units above the measured one; the whole stated range lies above it.
By their numbers in this assay, from the lowest: compounds 3 and 1 (each within the scatter of the next); then compound 2.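

In this assay, 2-methoxyphenyl in place of 3-ethylphenyl on an amide-type nitrogen gives a number 1.03 log units lower from compound 2 to compound 3 (beyond the scatter), a large step that shows this position can carry a big change in the read-out even though both groups have the same number of heavy atoms. Adding a methoxy group gives a number 0.12 log units lower from compound 1 to compound 3 (within the scatter), whereas ethyl in place of hydrogen gave a number 0.91 log units higher from compound 1 to compound 2 (beyond the scatter), so across these three compounds only the ethyl substitution moves the number beyond the usual scatter. Nothing measured here explains why these two substitutions behave so differently.

The names 3-ethylphenyl and 2-methoxyphenyl differ both in the group and in the number that gives its place on the ring, so the compounds shown cannot separate the effect of the group from the effect of its place. From the compounds shown here alone, it also remains open how this read-out would respond to other groups on the same ring, such as a longer chain like propyl, a chlorine atom or an amine.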